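The source may report more compounds than this note shows. Statements on the series, on what has been measured and on what is new or still open speak of the compounds shown alone.

Measured so far in an ADME assay on a cell-free system (plasma, Homo sapiens) for metabolic stability, read by LC-MS; a higher number here means that the compound lasts longer, a lower number that the compound disappears faster:
- compound 1 `NCc1ccc(C(=O)Nc2ccncc2F)cc1-c1cccc(NC(=O)c2cccc(C(=O)O)c2)c1`: > 2 h
- compound 2 `NCc1ccc(C(=O)Nc2ccncc2F)cc1-c1cccc(C(=O)Nc2cccc(CC(=O)O)c2)c1`: > 2 h
- compound 3 `NCc1ccc(C(=O)Nc2ccncc2F)cc1-c1cccc(C(=O)OCC2CCCO2)c1`: < 0.0834 h

All three entries are limits, so no exact half-life is available in this set. Compound 1 gives > 2 h, which is a limit and not a number. It shares the limit of > 2 h in this assay, at which 2 of the 3 values shown sit, with compound 2, and only compound 3 lies at the other end, at the limit of < 0.0834 h in this assay, at which 1 of the 3 values shown sits.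

The next compound is compound 4 `COC(=O)c1ccc(C(=O)Nc2cccc(-c3cc(C(=O)Nc4ccncc4F)ccc3CN)c2)cc1`, reached from compound 1 by 4-(methoxycarbonyl)phenyl in place of 3-carboxyphenyl on a carbonyl carbon. In words, 4-(methoxycarbonyl)phenyl replaces 3-carboxyphenyl on a carbonyl carbon, and the amide-type nitrogen stays.

Within the data shown here, no measured step makes this exact change. The two nearest are an at least 23-fold lower number from compound 1 to compound 3 (1.37 log units; beyond the scatter) and an at least 23-fold lower number from compound 2 to compound 3 (1.37 log units; beyond the scatter), both large and both beyond the scatter. Across these three compounds, the two with a carboxylic acid sit at the upper limit, while compound 3, with its ((oxolan-2-yl)methoxy)carbonyl group, sits at the lower one. Compound 4 also carries an alkoxy group on a carbonyl, so it is expected to fall towards compound 3 in this assay. The expected drop is probably smaller than an at least 23-fold lower number from compound 1 to compound 3 (1.37 log units; beyond the scatter), as the change is confined to the group on the amide carbonyl.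

The estimated step is an at least 6.6-fold lower number from compound 1 to compound 4 (0.82 log units; beyond the scatter), a lower number and expected to lie beyond the scatter. The expected half-life of compound 4 is 0.3 h, with an estimated range of 0.08 h to 2 h.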

Compound 4, half-life: > 2 h
Compound 4: a limit, no number; the forecaster's own chance of this, stated with the estimate: 45%; middle value at least 6.6-fold (0.82 log units) from the limit.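

In this assay compound 4 gives > 2 h, which is a limit. Compound 1 gives > 2 h, also a limit. No step can be read between compound 1 and compound 4. The compounds shown leave open how far, if at all, 4-(methoxycarbonyl)phenyl in place of 3-carboxyphenyl moves the half-life.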